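Hydroxylamine in place of primary amide on the fluoroindole chain

The source may hold more compounds than are shown below. What is called first, only, known or untested is meant among the compounds shown, and "the series" means these compounds.

Measured so far:
compound 1 `NCCSCCc1c[nH]c2ccc(F)cc12` 8 nM
compound 2 `NC(=O)CCc1c[nH]c2ccc(F)cc12` 34 nM

In an assay on isolated protein for inhibition of Myeloperoxidase (Homo sapiens), read by ELISA, with a stated time of 5 min (on this read-out higher numbers stand for weaker inhibition and lower numbers for stronger inhibition), compound 2 gives 34 nM, the higher of the two numbers; compound 1 gives 8 nM. Among the compounds with values here, the one measured step, a 4.3-fold higher number from compound 1 to compound 2 (0.63 log units; beyond the scatter), swapped a chain carrying an amine nitrogen for carbamoyl and raised the number beyond the scatter.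

Compound 3 `ONCCCc1c[nH]c2ccc(F)cc12` differs from compound 2 by (hydroxyamino)methyl in place of carbamoyl on a saturated chain carbon, two bonds along the chain from an aromatic carbon. Within the data shown here, no measured pair isolates this exchange. Among the measured compounds shown here, the only bearing comes from compound 1, whose (2-aminoethyl)sulfanyl group likewise carries an amine-type nitrogen and gave the lower number in the measured step. On that slender basis a modest fall in the number is expected from compound 2 to compound 3, a 2.8-fold lower number from compound 2 to compound 3 (0.45 log units; beyond the scatter), rather than no change. Compound 3 is therefore estimated at 12 nM, within 4 nM to 40 nM.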

Compound 3, half-maximal inhibitory concentration: 21 nM
For compound 3 the middle estimate is 1.8-fold (0.24 log units) below the measured one; the measured number falls inside the stated range.
By their numbers in this assay, from the lowest: compound 1; then compounds 3 and 2 (each within the scatter of the next).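

In this assay, (hydroxyamino)methyl in place of carbamoyl gives a 1.6-fold lower number from compound 2 to compound 3 (0.21 log units; within the scatter) and so does not separate the two compounds at this place, although the groups differ in their atoms' arrangement and in what is counted as hydrogen-bond donors and acceptors. The (2-aminoethyl)sulfanyl chain still stands apart, with a 2.6-fold higher number from compound 1 to compound 3 (0.42 log units; beyond the scatter) as the read-out, so a nitrogen on the chain in the (hydroxyamino)methyl form does not by itself reach the level of compound 1. No measurement here gives a reason for either step.

Open, on these data alone, is whether the sulfur atom, the terminal primary amine or the chain length carries the gap to compound 1. A 3-aminopropyl chain, a carboxylic acid or a longer chain ending in hydroxyamino would bear on this.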